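Oxygen-to-sulfur swap in a sulfonyl-linked ring, second core

The source may report more compounds than this note shows. Statements on the series, on what has been measured and on what is new or still open speak of the compounds shown alone.

This account follows two pairs of compounds built on related cores. Compound 2 `COc1ccc(C2=NN(c3ccccc3)C(c3ccc(C)cc3)C2S(=O)(=O)CC2=NCCO2)cc1` and compound 3 `COc1ccc(C2=NN(c3ccccc3)C(c3ccc(C)cc3)C2S(=O)(=O)CC2=NCCS2)cc1` share one core; compound 1 `O=S(=O)(CC1=NCCO1)C1C(c2ccc(Cl)cc2)=NN(c2ccccc2)C1c1ccc(Cl)cc1` and compound 4 `O=S(=O)(CC1=NCCS1)C1C(c2ccc(Cl)cc2)=NN(c2ccccc2)C1c1ccc(Cl)cc1` share another. How the two cores differ is not broken down here.

In a functional assay, tested at 100 ug/mL (a lower number here means a weaker effect, a higher number a stronger effect of the compound at the concentration tested), compound 2 gives 67.7%, while compound 3 gives 47.9%. Among the measured compounds shown here, the single change between them is a group of 5 heavy atoms (3 carbon, 1 nitrogen, 1 sulfur; one five-membered non-aromatic ring with 2 hetero atoms) in place of a group of 5 heavy atoms (3 carbon, 1 nitrogen, 1 oxygen; one five-membered non-aromatic ring with 2 hetero atoms), on a saturated chain carbon bound to a sulfonyl sulfur, and it produced a number 19.8 percentage points lower from compound 2 to compound 3 (beyond the scatter).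

Compound 1 is reported in this assay as "not active" (no number reported), with no number attached. Compound 4 carries the same change relative to compound 1, namely (a group of 5 heavy atoms (3 carbon, 1 nitrogen, 1 sulfur; one five-membered non-aromatic ring with 2 hetero atoms) in place of a group of 5 heavy atoms (3 carbon, 1 nitrogen, 1 oxygen; one five-membered non-aromatic ring with 2 hetero atoms), on a saturated chain carbon bound to a sulfonyl sulfur), and has not yet been measured.

Because compound 1 is recorded as "not active" (no number reported), there is no baseline number from which a step can be counted, and the earlier step of a number 19.8 percentage points lower from compound 2 to compound 3 (beyond the scatter) ran downward. The expectation for compound 4 is therefore a weak read-out in this assay, estimated around 10%, with a range from 0% to 30%, and a real chance that the assay again reports no number at all.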

Compound 4, a percentage reported as activity, at one concentration (the size of the read-out at that concentration, not a potency): "not active" (no number reported)
Compound 4 has no reported number here; there is nothing to compare the estimate with.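

In this assay compound 1 is recorded as "not active" (no number reported) and compound 4 as "not active" (no number reported), so no step can be read between them. No measured evidence bearing on this result is available here. The compounds shown leave open whether the drop seen on the core of compound 2 has any counterpart on the core of compound 1.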